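The source may report more compounds than this note shows. Statements on the series, on what has been measured and on what is new or still open speak of the compounds shown alone.

Compound 1 `CC1=CC[C@H](C(C)(C)NC(=S)N/N=C/c2ccc(F)cc2)CC1`, compound 2 `CC1=CC[C@H](C(C)(C)NC(=S)N/N=C/c2ccco2)CC1`. In a functional assay on UACC-62 cells (Homo sapiens) for inhibition, read by sulforhodamine B assay, with a stated time of 48 h (a higher number here means a weaker inhibitor of growth, a lower number a stronger inhibitor of growth), compound 1 reaches only a limit, > 100000 nM. In this assay compound 2 gives 10700 nM, the only number shown. For the measured compounds named here, the one other value shown is a limit (the limit of > 100000 nM in this assay, at which 1 of the 2 values shown sits). Compound 3 `CC1=CC[C@H](C(C)(C)NC(=S)N/N=C/c2cccs2)CC1` differs from compound 2 by thiophen-2-yl in place of furan-2-yl on a carbon with a double bond to nitrogen. Going by the values given here, the single measured step, an at least 9.3-fold lower number from compound 1 to compound 2 (0.97 log units; beyond the scatter), concerns a different ring exchange and gives little guidance for swapping one five-membered aromatic ring for another. Compound 3 is therefore expected to stay near compound 2, with an estimated step of a 1.1-fold higher number from compound 2 to compound 3 (0.05 log units; within the scatter) in this assay, not beyond the scatter. The estimate for compound 3 is 12000 nM, between 4000 nM and 40000 nM.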

Compound 3, concentration for 50% growth inhibition: 2600 nM
Estimate against measurement, compound 3: 4.6-fold (0.66 log units) above; the measured number lies below the stated range.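

At this place, on a carbon with a double bond to nitrogen, the two five-membered aromatic rings are not interchangeable: thiophen-2-yl in place of furan-2-yl gives a 4.1-fold lower number from compound 2 to compound 3 (0.61 log units; beyond the scatter) in this assay. Set against 4-fluorophenyl, thiophen-2-yl gives an at least 38-fold lower number from compound 1 to compound 3 (1.58 log units; beyond the scatter). Compound 1 stands at a limit, not a number: the limit of > 100000 nM in this assay, at which 1 of the 3 values shown sits. As far as these compounds go, whether a ring containing nitrogen, such as pyridin-2-yl, or a thiophene carrying a methyl group would lower the number further remains open. So does whether the order of these rings holds in other cell lines.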